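From 3-chlorophenyl to 4-methoxyphenyl in a cytotoxicity series

This account rests on a few compounds, and the source may have more. Where it says the series, first, only, none or still open, it means among the compounds named here.

Of the compounds shown here, three with a shared core have been measured in a toxicity assay on MT4 cells (Homo sapiens) for cytotoxicity, read by MTT assay; on this read-out lower numbers stand for higher toxicity in this test and higher numbers for lower toxicity in this test. Compound 1 (`COc1cc(-c2ccc(C#N)cc2)ccc1Oc1cc(N)nc(Nc2ccc(C#N)cc2)n1`) gives 120000 nM, compound 2 (`Cc1cc(Oc2cc(N)nc(Nc3ccc(C#N)cc3)n2)ccc1-c1ccc(C#N)cc1`) gives 34300 nM, and compound 3 (`Cc1cc(-c2cccc(Cl)c2)cc(C)c1Oc1cc(N)nc(Nc2ccc(C#N)cc2)n1`) gives 22300 nM. Compound 3 and compound 2 lie within the usual scatter of each other, while compound 1 has a higher number than compound 3, beyond that scatter.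

Compound 4 (`COc1ccc(-c2cc(C)c(Oc3cc(N)nc(Nc4ccc(C#N)cc4)n3)c(C)c2)cc1`) has not yet been measured. It carries 4-methoxyphenyl in place of 3-chlorophenyl on an aromatic carbon, meta to two methyl groups (4-methoxyphenyl in place of 3-chlorophenyl on an aromatic carbon). Among the measured compounds shown here, no two measured compounds differ in one place only, so this exchange has no direct precedent. The measured numbers run from compound 3 at 22300 nM to compound 1 at 120000 nM, so a step beyond the scatter is not expected. The estimated change is a 1.3-fold higher number from compound 3 to compound 4 (0.13 log units; within the scatter), a slight rise that stays within the scatter. For compound 4 the expected value is 30000 nM, with an estimated range of 12000 nM to 80000 nM.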

Compound 4, half-maximal cytotoxic concentration: 10700 nM
For compound 4 the middle estimate is 2.8-fold (0.45 log units) above the measured one; the measured number lies below the stated range.
By their numbers in this assay, from the lowest: compound 4; then compounds 3 and 2 (each within the scatter of the next); then compound 1.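

In this assay, among the compounds shown here, the exchange of 3-chlorophenyl for 4-methoxyphenyl gives a 2.1-fold lower number from compound 3 to compound 4 (0.32 log units; beyond the scatter) and so provides the first reading of a change made in one place only. The step is modest but beyond the usual scatter, and it shows that the group on this aromatic carbon, meta to two methyl groups and para to a large group, can shift the number toward higher toxicity in this test. Nothing given here explains that shift. As far as these compounds go, what stays open is whether the step follows the change of substituent, the change of its place on the phenyl ring, or both. A 4-chlorophenyl or a 3-methoxyphenyl at this position would separate those two changes, and an unsubstituted phenyl would give a common point of comparison.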